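A few compounds are considered here, and "the series" means these few. Any claim that something is new, unique, unknown or untested is made for them only; others in the source may bear on it.

Compound 1, `CCOC(=O)C1=Cc2ccccc2OC1(OCc1cn(-c2cccc(OC)c2)nn1)C(F)(F)F`, and compound 2, `CCOC(=O)C1=Cc2ccccc2OC1(OCc1cn(-c2cccc(C(F)(F)F)c2)nn1)C(F)(F)F`, share one core and differ only in a single group on an aromatic carbon. In a functional assay on MCF7 cells (Homo sapiens) for inhibition, read by MTT assay, with a stated time of 24 h (on this read-out lower numbers stand for stronger inhibition and higher numbers for weaker inhibition), compound 1 reaches only a limit of the assay, > 150000 nM. In this assay compound 2 likewise stands at a limit, > 150000 nM. Trifluoromethyl in place of methoxy on an aromatic carbon gives a step that the two limits leave unreadable from compound 1 to compound 2, because both ends of that step sit at the limit of > 150000 nM in this assay, at which 2 of the 2 values shown sit. Compound 2 therefore stands at the assay limit, and every number shown sits there with it. Compound 3, `CCOC(=O)C1=Cc2ccccc2OC1(OCc1cn(-c2ccc([N+](=O)[O-])cc2)nn1)C(F)(F)F`, has not yet been measured in this assay; it differs from compound 2 by 4-nitrophenyl in place of 3-(trifluoromethyl)phenyl on an aromatic nitrogen. Within the data shown here, the only measured step touches a different place and is of unreadable size, so neither direction nor size can be read from it for this change. The expectation for compound 3 in this assay is 150000 nM, within a range from 50000 nM to 400000 nM. The step expected from compound 2 to compound 3 is thus a number no higher from compound 2 to compound 3 (the limit leaves the size open), most likely a further limit rather than a number.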

Compound 3, half-maximal inhibitory concentration: > 150000 nM
Compound 3: a limit, no number; the forecaster's own chance of this, stated with the estimate: 75%; the middle value sits exactly at the limit.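

In this assay compound 3 gives > 150000 nM as a limit of the assay and not a number. Among these compounds, no step among compound 1, compound 2 and compound 3 can be read, because all three stand at the same limit: the limit of > 150000 nM in this assay, at which 3 of the 3 values shown sit. The compounds shown leave open how strongly any of them inhibits, and whether changing the group on the aromatic nitrogen alters that at all.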